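A few compounds are considered here, and "the series" means these few. Any claim that something is new, unique, unknown or untested is made for them only; others in the source may bear on it.

Among the measured compounds shown here, compounds with numbers so far: compound 1 `CN1CCN(CC(=O)NC2CC3(N4CCCC4)CC(c4ccccc4)C2C(c2ccccc2)C3)CC1` gives 50200 nM in an ADME assay on L6 cells (Rattus norvegicus) for cytotoxicity, read by resazurin assay, with a stated time of 72 h; on this read-out lower numbers stand for stronger inhibition and higher numbers for weaker inhibition; compound 2 `CCN(CC)CC(=O)OC1CC2(N3CCCCC3)CC(c3ccccc3)C1C(c1ccccc1)C2` gives 23900 nM; compound 3 `CN1CCN(CC(=O)OC2CC3(N4CCCCC4)CC(c4ccccc4)C2C(c2ccccc2)C3)CC1` gives 29500 nM.

Compound 3 holds the second highest of the three numbers; its nearest neighbour is compound 2, and the step of a 1.2-fold higher number from compound 2 to compound 3 (0.09 log units; within the scatter) is within the scatter. Compound 4 `CN1CCN(CC(=O)NC2CC3(N4CCCCC4)CC(c4ccccc4)C2C(c2ccccc2)C3)CC1` differs from compound 3 in one place: (((4-methylpiperazin-1-yl)methyl)carbonyl)amino in place of (((4-methylpiperazin-1-yl)methyl)carbonyl)oxy on a saturated ring carbon. For the measured compounds named here, no measured step covers this change. Compound 1 carries the same carbonylamino group but also a different ring on the other side, so only its two values with compound 3 can be compared, and they lie within the scatter of each other. Compound 4 is therefore expected to show a 1.4-fold higher number from compound 3 to compound 4 (0.13 log units; within the scatter), no move beyond the scatter. The estimate for compound 4 is 40000 nM, within 20000 nM to 80000 nM.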

Compound 4, half-maximal inhibitory concentration: 57500 nM
For compound 4 the middle estimate is 1.4-fold (0.16 log units) below the measured one; low and high end bracket the measured number.
By their numbers in this assay, from the lowest: compounds 2, 3, 1 and 4 (each within the scatter of the next, the first and the last beyond it).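

In this assay, among the compounds shown here, the carbonylamino link in place of the carbonyloxy link on the saturated ring carbon gives a 1.9-fold higher number from compound 3 to compound 4 (0.29 log units; within the scatter) and so stays within the scatter, whereas changing the diethylamino group as well gives a 2.4-fold higher number from compound 2 to compound 4 (0.38 log units; beyond the scatter) as the only step here beyond it. Piperidin-1-yl in place of pyrrolidin-1-yl, now seen on the carbonylamino series, gives a 1.1-fold higher number from compound 1 to compound 4 (0.06 log units; within the scatter) with no move beyond the scatter. No measured evidence bears on these steps.
Open, as far as these compounds go, is whether a longer chain between the carbonyl and the 4-methylpiperazin-1-yl group, or a morpholin-4-yl group in its place, would shift the number beyond the scatter.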